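The source may report more compounds than this note shows. Statements on the series, on what has been measured and on what is new or still open speak of the compounds shown alone.

Measured so far:
compound 1, `Cc1ccc2c(=S)cc(-c3ccccc3)oc2c1`: "not active" (no number reported)
compound 2, `Fc1ccc2c(=S)cc(-c3ccccc3)oc2c1`: 40%

The study examines two thione analogues on a shared core. In an in vitro assay on BTI-TN-5B1-4 cells for inhibition of Amine oxidase [flavin-containing] A (Homo sapiens), tested at 100 uM (on this read-out higher numbers stand for more inhibition at the one concentration tested (going by the name of the read-out) and lower numbers for less inhibition), compound 1 is reported as "not active" (no number reported), with no single number attached. In this assay compound 2 gives 40%, which is the only number shown in this set; the one further entry, compound 1, carries no single number. For the measured compounds named here, compound 2 therefore stands as the sole quantified point, and no step between measured compounds can be counted.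

The next compound, compound 3 with structure `COc1ccc2c(=S)cc(-c3ccccc3)oc2c1`, differs from compound 2 in one place: methoxy in place of fluoro on an aromatic carbon. With methoxy in place of fluoro on that aromatic carbon, and with compound 1 reported as "not active" (no number reported), a fall in this assay of moderate size is expected rather than a rise, but the ground for the expectation is thin. The estimated step from compound 2 to compound 3 is a number 15 percentage points lower from compound 2 to compound 3 (beyond the scatter), a drop somewhat larger than the scatter. Compound 3 is expected to give 25% in this assay, within a range from 0% to 55%.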

Compound 3, a percentage reported as inhibition, at one concentration (the size of the read-out at that concentration, not a potency): "not active" (no number reported)
For compound 3 the study gives words and no number, so the estimate cannot be set against anything.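

In this assay, for the compounds shown here, compound 3 is reported as "not active" (no number reported) and so, with no number to set against compound 2, no step between the two can be read. No measurement shown here bears on this result. The compounds shown leave open how much inhibition, if any, compound 1 and compound 3 retain compared with compound 2.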